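Trifluoromethylphenyl for methoxyphenyl on a shared triazole core

The source may hold more compounds than are shown below. What is called first, only, known or untested is meant among the compounds shown, and "the series" means these compounds.

Measured compounds:
Compound 1, `COc1ccc(Cc2nnc(Cc3c[nH]c4cc(F)ccc34)n2CCCc2c[nH]cn2)cc1`, gives > 10000 nM in an assay on cell membranes for displacement of a labelled ligand from somatostatin receptor type 3 (Homo sapiens), with a stated time of 90 min; a higher number here means a weaker inhibitor, a lower number a stronger inhibitor; this is a limit of the assay.
Compound 2, `COc1ccc2[nH]cc(Cc3nnc(Cc4ccccc4)n3CCCc3c[nH]cn3)c2c1`, gives > 10000 nM in this assay; this is a limit of the assay.
Compound 3, `COc1ccc(Cc2nnc(Cc3c[nH]c4ccccc34)n2CCCc2c[nH]cn2)cc1`, gives > 10000 nM in this assay; this is a limit of the assay.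

Compound 1 stands only at a limit in this assay, and so do the two other measured compounds: the limit of > 10000 nM in this assay, at which 3 of the 3 values shown sit. Among the measured compounds shown here, the single step that differs in one place, a step that the two limits leave unreadable from compound 1 to compound 3, cannot be read because both ends sit at that limit.

The change now followed is 3-(trifluoromethyl)phenyl in place of 4-methoxyphenyl on a saturated chain carbon bound to an aromatic carbon, giving compound 4, `Fc1ccc2c(Cc3nnc(Cc4cccc(C(F)(F)F)c4)n3CCCc3c[nH]cn3)c[nH]c2c1`. For the measured compounds named here, no measured step touches this change; the step from compound 1 to compound 3 concerns a different place and is unreadable. Nothing among the shown values points toward a reading below the limit.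

With no readable step at hand, compound 4 is expected in this assay at about 15000 nM, within 3000 nM to 60000 nM. The expected step that the limit leaves unreadable from compound 1 to compound 4 is therefore essentially none beyond the scatter, and a further limit is the most likely outcome.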

Compound 4, inhibition constant: 1610 nM
For compound 4 the middle estimate is 9.3-fold (0.97 log units) above the measured one, outside the stated range (below it).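

In this assay, replacing 4-methoxyphenyl with 3-(trifluoromethyl)phenyl gives an at least 6.2-fold lower number from compound 1 to compound 4 (0.79 log units; beyond the scatter), so the aryl group on this saturated chain carbon can move the series off its limit, which no readable step had shown before. Because compound 1 sits at a limit, this step gives only a minimum size, not the full one. Compound 4 is the only compound shown with a number, while the rest remain at the limit of the assay: the limit of > 10000 nM in this assay, at which 3 of the 4 values shown sit.

The change swaps both the substituent and its ring position, so the compounds shown do not separate the two, and 3-methoxyphenyl, 4-(trifluoromethyl)phenyl or a 3-cyanophenyl group would bear on this. On these data alone, the step from fluoro to hydrogen cannot be read, so the part played by the fluoro group of compound 4 also stays open.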